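The source may report more compounds than this note shows. Statements on the series, on what has been measured and on what is new or still open speak of the compounds shown alone.

Among the compounds with values here, compound 3 `O=S(=O)(c1cccc(Cl)c1)c1cn(C2CCCNC2)c2ncccc12` gives the highest of the three numbers so far in a functional assay on HeLa cells for agonist activity at 5-hydroxytryptamine receptor 6 (Homo sapiens), read by cAMP accumulation and immunoassay (a lower number here means a smaller maximal response, a higher number a larger maximal response), 49%. Compound 1 `O=S(=O)(c1cccc(F)c1)c1cn(C2CCNC2)c2ncccc12` gives 44%, a number within the scatter of compound 3, so the two cannot be ordered. Compound 2 `O=S(=O)(C1=C(Cl)NC2SC=CN12)c1cn(C2CCNC2)c2ncccc12` gives 32%, a number beyond the scatter below compound 3. Compound 4 `O=S(=O)(C1=C(Cl)NC2SC=CN12)c1cn(C2CCCNC2)c2ncccc12` differs from compound 3 by the change (a group of 9 heavy atoms (5 carbon, 2 nitrogen, 1 sulfur, 1 chlorine; 2 five-membered non-aromatic rings with 2 hetero atoms each) in place of a group of 7 heavy atoms (6 carbon, 1 chlorine; one six-membered aromatic ring of carbon only), on a sulfonyl sulfur). Because compound 2 carries the entering group and gives 32% while compound 1 gives 44%, the step from compound 3 to compound 4 is expected to be downward and beyond the scatter, around a number 12 percentage points lower from compound 3 to compound 4 (beyond the scatter). Compound 4 is therefore estimated at 37% in this assay, with a range from 22% to 52%.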

Compound 4, largest response reached (Emax), in percent of the reference or control that the assay uses: 47%
Compound 4: the middle estimate sits 10 percentage points below what was measured; the range from low to high includes it.
By their numbers in this assay, from the lowest: compound 2; then compounds 1, 4 and 3 (each within the scatter of the next).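

With the piperidin-3-yl group held constant, the change at the sulfonyl sulfur gives a number 2 percentage points lower from compound 3 to compound 4 (within the scatter), so 3-chlorophenyl and the entering group cannot be told apart in this assay. With that entering group held constant, piperidin-3-yl in place of pyrrolidin-3-yl on the aromatic nitrogen gives a number 15 percentage points higher from compound 2 to compound 4 (beyond the scatter), the first ring-size step shown. No supporting evidence bears on why either step takes this size. From the compounds shown here alone, compounds 1 and 3 differ in two places, so whether the ring-size step also holds with an aromatic group on the sulfonyl sulfur stays open. Going by these compounds, how a 3-methoxyphenyl group would compare at that sulfur also remains open.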